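This account rests on a few compounds, and the source may have more. Where it says the series, first, only, none or still open, it means among the compounds named here.

Compound 1 `O=C(NN1CCOCC1)c1c(O)c2cccnc2n(-c2ccccc2)c1=O`: -8.5%
Compound 2 `Cc1ccc(NC(=O)c2c(O)c3cccnc3n(-c3ccccc3)c2=O)cc1`: -3.5%
Compound 3 `O=C(Nc1ccncc1)c1c(O)c2cccnc2n(-c2ccccc2)c1=O`: 34.9%

Of the compounds shown here, three sharing one core have been tested in a functional assay on the whole organism for inhibition, with Rattus norvegicus as the target, read by paw edema, at a dose of 100 mg/kg by the oral route; a lower number here means less inhibition, a higher number more inhibition at the dose given (going by the name of the read-out). Compound 1 gives -8.5%, the lowest of the three numbers. Its nearest neighbour is compound 2, and the step of a number 5 percentage points higher from compound 1 to compound 2 (within the scatter) lies within the scatter, so the two cannot be told apart. Compound 3 stands furthest away: the step of a number 43.4 percentage points higher from compound 1 to compound 3 (beyond the scatter) is large and beyond the scatter, as is a number 38.4 percentage points higher from compound 2 to compound 3 (beyond the scatter).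

Compound 4 `Cc1cnccc1NC(=O)c1c(O)c2cccnc2n(-c2ccccc2)c1=O` has not yet been measured in this assay. It differs from compound 1 in one place: 3-methylpyridin-4-yl in place of morpholin-4-yl on an amide-type nitrogen. The measured step that bears most on this change is a number 43.4 percentage points higher from compound 1 to compound 3 (beyond the scatter), where a pyridin-4-yl entered at the same amide-type nitrogen. Going by the values given here, compound 4 carries a 3-methylpyridin-4-yl there instead, and no measured step shows what the added methyl does by itself. A large rise beyond the scatter is therefore expected, close to the step seen for compound 3: a number 38.5 percentage points higher from compound 1 to compound 4 (beyond the scatter). Compound 4 is estimated to give about 30%, with a range from 5% to 50%.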

Compound 4, a percentage reported as inhibition, in the whole organism at one dose (the size of the read-out at that dose, not a potency): 26.9%
Compound 4: middle estimate off by 3.1 percentage points, on the high side; low and high end bracket the measured number.
By their numbers in this assay, from the lowest: compounds 1 and 2 (each within the scatter of the next); then compounds 4 and 3 (each within the scatter of the next).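

In this assay, placing a methyl on an aromatic carbon of the pyridin-4-yl group gives a number 8 percentage points lower from compound 3 to compound 4 (within the scatter), so compound 3 and compound 4 cannot be told apart. The methyl-bearing ring also keeps a clear gap from the morpholin-4-yl group, with a number 35.4 percentage points higher from compound 1 to compound 4 (beyond the scatter), and from the 4-methylphenyl group, with a number 30.4 percentage points higher from compound 2 to compound 4 (beyond the scatter). Among these four compounds, the two with a pyridine-type ring on the amide-type nitrogen both stand apart from the two without one, and no compound shown goes against this pattern.

As far as these compounds go, whether an amine, a carboxylic acid or a longer chain in place of that methyl would keep the number stays open. Nothing available gives a reason for the gap between these two pairs of compounds.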